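The compounds below may be only part of what the source reports. "The series", "measured", "known", "first", "only" and "open" are said of these compounds alone.

Measured compounds:
- compound 1 `COc1ccc(-n2sc(=O)n(-c3ccc(OC)cc3)c2=O)cc1`: < 2000 nM in an ADME assay, in phosphate buffer, with a stated time of 30 min, tested at 1 mM, at a dose of 1 mM; on this read-out lower numbers stand for lower exposure and higher numbers for higher exposure at the dose given
- compound 2 `COc1ccc(-n2sc(=O)n(-c3ccccc3)c2=O)cc1`: < 2000 nM
- compound 3 `O=c1sn(-c2ccccc2)c(=O)n1-c1ccccc1`: < 2000 nM

In this assay compound 3 gives only a limit, not a number. All values shown sit at the same point, as the limit of < 2000 nM in this assay, at which 3 of the 3 values shown sit, records. The step that the two limits leave unreadable from compound 1 to compound 2 and the step that the two limits leave unreadable from compound 2 to compound 3 are therefore unreadable, and they give no measure of how far a change at this position moves the read-out.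

Compound 4 `Cc1ccc(-n2sc(=O)n(-c3ccccc3)c2=O)cc1` differs from compound 3 by methyl in place of hydrogen on an aromatic carbon. Going by the values given here, no measured step touches a methyl, and the two measured steps are unreadable, so nothing argues for a move beyond the scatter. The expected step that the limit leaves unreadable from compound 3 to compound 4 is set near zero. Compound 4 is estimated at 1000 nM in this assay, within 250 nM to 3000 nM, most likely reported again only as a limit.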

Compound 4, maximal plasma concentration: < 2000 nM
Compound 4 was reported as a limit (the forecaster's own chance of this, stated with the estimate: 85%); the middle value is on the limit's open side.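

Compound 4 is also recorded only as a limit, so its steps from compound 3 and compound 2 cannot be read: the limit of < 2000 nM in this assay, at which 4 of the 4 values shown sit. The compounds shown leave open how far any of these aromatic substitutions moves the read-out in this assay.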